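The compounds below may be only part of what the source reports. "The series", "measured", "known", "first", "only" and "open" are said of these compounds alone.

Measured so far in an assay for inhibition of Fatty-acid amide hydrolase 1 (Rattus norvegicus); on this read-out lower numbers stand for stronger inhibition and higher numbers for weaker inhibition:
compound 1 `N#Cc1cccc(-c2cnc(C(=O)CCc3ccc(COc4ccccc4)cc3)o2)n1` gives 0.56 nM
compound 2 `O=C(CCc1ccc(COc2ccccc2)cc1)c1ncco1` gives 25 nM
compound 3 `CNC(=O)c1cnc(C(=O)CCc2ccc(COc3ccccc3)cc2)o1` gives 3.6 nM

Compound 3 holds the second highest of the three numbers in this assay. Toward the lower end, a 6.4-fold higher number from compound 1 to compound 3 (0.81 log units; beyond the scatter); toward the upper end, a 6.9-fold lower number from compound 2 to compound 3 (0.84 log units; beyond the scatter). The whole span of the series is set by a 45-fold higher number from compound 1 to compound 2 (1.65 log units; beyond the scatter).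

Compound 4 `O=C(CCc1ccc(COc2ccccc2)cc1)c1ncc(-c2cccc(-c3nnn[nH]3)n2)o1` is not yet measured. The change from compound 3 is 6-(1H-tetrazol-5-yl)pyridin-2-yl in place of methylcarbamoyl on an aromatic carbon. Among the measured compounds shown here, two measured steps bear on it: the carbon-linked 6-cyanopyridin-2-yl group of compound 1 sits well below the methylcarbamoyl of compound 3, and the methylcarbamoyl itself sits well below hydrogen in compound 2. For the measured compounds named here, the entering group shares its pyridin-2-yl part with the group of compound 1, while the 1H-tetrazol-5-yl part has no precedent. A step beyond the scatter, downward, is therefore expected for compound 4, of roughly the size a 3.6-fold lower number from compound 3 to compound 4 (0.56 log units; beyond the scatter), resting on compound 1 with a 6.4-fold higher number from compound 1 to compound 3 (0.81 log units; beyond the scatter). The estimated value for compound 4 in this assay is 1 nM, expected within 0.3 nM to 4 nM.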

Compound 4, inhibition constant: 21 nM
The estimate for compound 4 lay 21-fold (1.32 log units) below the measured number; the whole stated range lies below it.
By their numbers in this assay, from the lowest: compound 1; then compound 3; then compounds 4 and 2 (each within the scatter of the next).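

In this assay, the pyridin-2-yl part does not by itself carry the low number of compound 1: with 1H-tetrazol-5-yl in place of cyano, the step is large (a 38-fold higher number from compound 1 to compound 4 (1.57 log units; beyond the scatter)), so the outcome at this position depends on the group carried by that part. At this place next to the ring oxygen, the full 6-(1H-tetrazol-5-yl)pyridin-2-yl group is within the scatter of hydrogen (a 1.2-fold lower number from compound 2 to compound 4 (0.08 log units; within the scatter)) and compares poorly with the much smaller methylcarbamoyl (a 5.8-fold higher number from compound 3 to compound 4 (0.77 log units; beyond the scatter)), so a large aromatic group here offers no gain on its own. Nothing measured on these compounds accounts for the gap between nitrile and tetrazole.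

Open, on these data alone, is where a plain pyridin-2-yl group falls, which would separate the contribution of that ring from that of the cyano group. Also open, as far as these compounds go, is whether a carboxylic acid or a primary amide in place of the tetrazole tracks compound 1 or compound 4.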